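Swapping a nitro for a fluoro on a low-toxicity scaffold

A few compounds are considered here, and "the series" means these few. Any claim that something is new, unique, unknown or untested is made for them only; others in the source may bear on it.

The study measures how much of each compound cultured cells tolerate, using an ADME assay on cells (Mus musculus, strain BALB/c) for cytotoxicity, read by MTT assay, with a stated time of 24 h; a higher number here means that more compound is tolerated, a lower number that less compound is tolerated. Compound 1, `COc1cc(-c2nnc(SCc3ccc(C)cc3)o2)ccc1O`, gives 549000 nM in this assay. Compound 2, `COc1cc(-c2nnc(SCc3ccccc3[N+](=O)[O-])o2)ccc1O`, gives 331000 nM in this assay, the lowest of the two numbers recorded so far, though its nearest neighbour, compound 1, sits within the usual scatter of it, so the two cannot be ordered.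

Compound 3, `COc1cc(-c2nnc(SCc3ccccc3F)o2)ccc1O`, is the untested member. It differs from compound 2 in one place: fluoro in place of nitro on an aromatic carbon. The group that leaves sits on an aromatic carbon of a six-membered aromatic ring of carbon only, ortho to a large group, and the fluoro enters at that same carbon. For the measured compounds named here, no measured pair in this set shows what such a swap does, so there is no step to lean on.

Given that both measured values lie far up the concentration range, compound 3 is expected to stay in the same region, with a step from compound 2 of a 1.3-fold higher number from compound 2 to compound 3 (0.10 log units; within the scatter) that would not exceed the scatter. The estimate for compound 3 in this assay is 420000 nM, with a range from 200000 nM to 850000 nM.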

Compound 3, half-maximal cytotoxic concentration: 474000 nM
Estimate against measurement, compound 3: 1.1-fold (0.05 log units) below; the measured number falls inside the stated range.
By their numbers in this assay, from the lowest: compounds 2, 3 and 1 (each within the scatter of the next).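

In this assay, putting fluoro in place of nitro on an aromatic carbon, ortho to a large group, gives a 1.4-fold higher number from compound 2 to compound 3 (0.16 log units; within the scatter) and so shows that, at this position, this swap has no effect that can be told from the scatter. The change at the other end of the sulfur, 2-fluorophenyl in place of 4-methylphenyl on a saturated chain carbon bound to a sulfur, gives a 1.2-fold lower number from compound 1 to compound 3 (0.06 log units; within the scatter) and so also stays within the scatter, which leaves the three compounds in one group that cannot be separated in this read-out. Nothing at hand offers a cause for this result.

The compounds shown leave open whether any group on this aromatic carbon can move the number beyond the scatter at all. On these data alone, an amine or a carboxylic acid in place of the fluoro would bear on that, a longer chain in place of the saturated chain carbon would test the link to the sulfur, and the effect of changes in the shared core remains unknown.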